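Compound 3 to compound 4: isopropyl to butyl

This account rests on a few compounds, and the source may have more. Where it says the series, first, only, none or still open, it means among the compounds named here.

Values in a functional assay on the whole organism with Mus musculus as the target, in the rotarod test; a higher number here means that more compound is needed for the effect, a lower number that less compound is needed:
- compound 1 `CN(C(=O)CNC(=O)CN1CCCCC1)c1ccc(Cl)cc1C(=O)c1ccccc1Cl`: > 100 mg/kg (a limit)
- compound 2 `CC(C)NCC(=O)NCC(=O)N(C)c1ccc(Cl)cc1C(=O)c1ccccc1Cl`: 13 mg/kg
- compound 3 `CC(C)C(=O)NCC(=O)N(C)c1ccc(Cl)cc1C(=O)c1ccccc1Cl`: > 100 mg/kg (a limit)

Compound 3 stands at > 100 mg/kg, which is a limit and not a number. The upper end of the series is the limit of > 100 mg/kg in this assay, at which 2 of the 3 values shown sit.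

Compound 4 `CCCCC(=O)NCC(=O)N(C)c1ccc(Cl)cc1C(=O)c1ccccc1Cl` carries butyl in place of isopropyl on a carbonyl carbon. Neither group carries a net charge.

Two measured steps change the group on this carbonyl carbon or the amine group it holds: an at least 7.6-fold higher number from compound 2 to compound 3 (0.88 log units; beyond the scatter) and an at least 7.6-fold lower number from compound 1 to compound 2 (0.88 log units; beyond the scatter). Within the data shown here, both are large, and both run through compound 2, the only compound with a number. The third step is a step that the two limits leave unreadable from compound 1 to compound 3. None of these replaces one plain carbon chain with another, so they give no direct size for the present change.

No step beyond the scatter is expected in this assay, and a further limit is the likeliest report for compound 4. The expected step is a step that the limit leaves unreadable from compound 3 to compound 4. For compound 4 the estimate is 150 mg/kg, with an expected range of 50 mg/kg to 300 mg/kg.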

Compound 4, dose for half-maximal effect: 90 mg/kg
For compound 4 the middle estimate is 1.7-fold (0.22 log units) above the measured one, within the range that was stated.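

In this assay, among these compounds, compound 4 gives 90 mg/kg, the first number for a plain carbon chain on this carbonyl carbon, so the distance from the isopropylamino compound can now be read directly: a 6.9-fold higher number from compound 2 to compound 4 (0.84 log units; beyond the scatter). The steps from the two limits are readable only as floors, an at least 1.1-fold lower number from compound 3 to compound 4 (0.04 log units; that floor lies within the scatter) and an at least 1.1-fold lower number from compound 1 to compound 4 (0.04 log units; that floor lies within the scatter), so butyl in place of isopropyl shows no difference that stands clear of the scatter, although a larger one is not excluded. Compound 1 and compound 3 remain limits and not numbers, which leaves every comparison with them bounded on one side only: the limit of > 100 mg/kg in this assay, at which 2 of the 4 values shown sit.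

Still open, going by these compounds, is whether a longer chain such as hexyl would lower the number further than butyl does, or leave it in the same region. Also open, on these data alone, is whether a smaller amine such as dimethylamino would match isopropylamino on the saturated chain carbon, since piperidin-1-yl in compound 1 is also an amine, yet its value is only a limit.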